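The source may report more compounds than this note shows. Statements on the series, on what has been measured and on what is new or still open speak of the compounds shown alone.

Working notes on the series, following the step from compound 2 to compound 4. Compound 1 `Cc1cn([C@@H]2O[C@H](CO[Si](C)(C)C(C)(C)C)[C@@]3(OS(=O)(=O)C=C3NCC(=O)O)[C@H]2O[Si](C)(C)C(C)(C)C)c(=O)n(C)c1=O` gives 30000 nM in a functional assay on MT4 cells (Homo sapiens); a lower number here means that less compound is tolerated, a higher number that more compound is tolerated. Compound 2 `Cc1cn([C@@H]2O[C@H](CO[Si](C)(C)C(C)(C)C)[C@@]3(OS(=O)(=O)C=C3NCC(=O)C(=O)N3CCC3)[C@H]2O[Si](C)(C)C(C)(C)C)c(=O)n(C)c1=O` gives 17400 nM in this assay. Compound 3 `CCOC(=O)CNC(=O)NC1=CS(=O)(=O)O[C@@]12[C@@H](CO[Si](C)(C)C(C)(C)C)O[C@@H](n1cc(C)c(=O)n(C)c1=O)[C@@H]2O[Si](C)(C)C(C)(C)C` gives 3780 nM in this assay. Compound 2 stands second highest of the three numbers, with compound 1 nearest and compound 3 furthest. Compound 4 `COC(=O)C(=O)CNC1=CS(=O)(=O)O[C@@]12[C@@H](CO[Si](C)(C)C(C)(C)C)O[C@@H](n1cc(C)c(=O)n(C)c1=O)[C@@H]2O[Si](C)(C)C(C)(C)C` differs from compound 2 as follows: methoxy in place of azetidin-1-yl on a carbonyl carbon. Among the compounds with values here, the only measured step at this place is a 1.7-fold lower number from compound 1 to compound 2 (0.24 log units; within the scatter), which stayed within the scatter; the steps of a 7.9-fold lower number from compound 1 to compound 3 (0.90 log units; beyond the scatter) and a 4.6-fold lower number from compound 2 to compound 3 (0.66 log units; beyond the scatter) change a different part of the chain. No step beyond the scatter is therefore expected in this assay. Compound 4 is estimated at 20000 nM, range 8000 nM to 40000 nM, an expected step of a 1.1-fold higher number from compound 2 to compound 4 (0.06 log units; within the scatter).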

Compound 4, half-maximal cytotoxic concentration: 10300 nM
Estimate against measurement, compound 4: 1.9-fold (0.29 log units) above, within the range that was stated.
By their numbers in this assay, from the lowest: compound 3; then compounds 4, 2 and 1 (each within the scatter of the next, the first and the last beyond it).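

In this assay, methoxy in place of azetidin-1-yl on a carbonyl carbon gives a 1.7-fold lower number from compound 2 to compound 4 (0.23 log units; within the scatter) and so does not separate these two groups. Methoxycarbonyl in place of hydroxy gives a 2.9-fold lower number from compound 1 to compound 4 (0.46 log units; beyond the scatter) and is the first step at this place beyond the scatter, whereas the (azetidin-1-yl)carbonyl step stayed within it. The chain of compound 4 also stands apart from that of compound 3, with a 2.7-fold higher number from compound 3 to compound 4 (0.44 log units; beyond the scatter) on the amine nitrogen.

Nothing available explains these steps. From the compounds shown here alone, whether a primary amine or isopropoxy on this carbonyl carbon would stay within the scatter of compound 4 remains open.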